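Acrylamide Chain Variation on a Pyrimidine Kinase Scaffold

The compounds below may be only part of what the source reports. "The series", "measured", "known", "first", "only" and "open" are said of these compounds alone.

Measured compounds:
Compound 1 `CCC/C=C\C(=O)Nc1cc(Nc2nccc(-c3cn(C)c4ccc(F)cc34)n2)c(OC)cc1N(C)CCN(C)C`: 2730 nM
Compound 2 `COc1cc(N(C)CCN(C)C)c(NC(=O)/C=C\C(C)C)cc1Nc1ncc(C#N)c(-c2cn(C)c3ccc(F)cc23)n1`: 1130 nM

In a functional assay on NCI-H1975 cells (Homo sapiens) for antiproliferative activity, read by MTT assay, with a stated time of 72 h (a lower number here means a stronger inhibitor, a higher number a weaker inhibitor), compound 2 gives 1130 nM, the lowest of the two numbers recorded. Its nearest neighbour is compound 1, which in this assay gives 2730 nM, a gap that lies beyond the usual scatter of repeated measurements. Compound 3 `CCC/C=C\C(=O)Nc1cc(Nc2ncc(C#N)c(-c3cn(C)c4ccc(F)cc34)n2)c(OC)cc1N(C)CCN(C)C` has not been measured. It differs from compound 2 in the acrylamide chain: propyl in place of isopropyl on a double-bonded chain carbon bound to a double-bonded chain carbon, so that the (3-methylbut-1-en-1-yl)carbonyl group becomes a (pent-1-en-1-yl)carbonyl group, with the same atoms joined differently. Among the compounds with values here, no measured pair shows this exact change, so its effect in this assay is not known from these data. A branched-to-linear swap on a three-carbon chain is expected to move the number little, and compound 3 is estimated to give 1300 nM, within 500 nM to 3500 nM. The expected step of a 1.2-fold higher number from compound 2 to compound 3 (0.06 log units; within the scatter) is therefore estimated to stay within the scatter.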

Compound 3, half-maximal inhibitory concentration: 2420 nM
Estimate against measurement, compound 3: 1.9-fold (0.27 log units) below, and the stated range covers the measured number.
By their numbers in this assay, from the lowest: compound 2; then compounds 3 and 1 (each within the scatter of the next).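

Compounds 1 and 2 differ in two places, and compound 3 separates those places. In this assay, the chain alone accounts for a modest step (  a 2.1-fold higher number from compound 2 to compound 3 (0.33 log units; beyond the scatter)  ), so propyl and isopropyl on a double-bonded chain carbon bound to a double-bonded chain carbon are not interchangeable here, although they carry the same atoms. With the propyl chain held fixed, cyano in place of hydrogen on an aromatic carbon leaves the two compounds within the scatter of each other (  a 1.1-fold lower number from compound 1 to compound 3 (0.05 log units; within the scatter)  ).

The compounds shown leave open whether cyano in place of hydrogen would read the same with isopropyl on the chain. They also leave open how a longer chain, such as hexyl, or a chain ending in a dimethylamino group would read. No independent measurement is available to explain either step.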